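Furan-3-yl in Place of Phenyl: Expected Tolerance

A few compounds are considered here, and "the series" means these few. Any claim that something is new, unique, unknown or untested is made for them only; others in the source may bear on it.

Compound 1, `CC(=O)c1ccc2c(c1)nc(-c1ccccc1)n2C1CCCCC1`: in an ADME assay on MDBK cells (Bos taurus) for cytotoxicity, read by MTT assay, with a stated time of 96 h (a lower number here means that less compound is tolerated, a higher number that more compound is tolerated), compound 1 sits at the limit > 100000 nM.
Compound 2, `CC(=O)c1ccc2c(c1)nc(-c1ccc(C(F)(F)F)cc1)n2C1CCCCC1`: in this assay compound 2 gives 52000 nM.

Compound 1 stands at a limit, not a number: the limit of > 100000 nM in this assay, at which 1 of the 2 values shown sits. Compound 3, `CC(=O)c1ccc2c(c1)nc(-c1ccoc1)n2C1CCCCC1`, differs from compound 1 by furan-3-yl in place of phenyl on an aromatic carbon. Among the compounds with values here, the only measured step, an at least 1.9-fold lower number from compound 1 to compound 2 (0.28 log units; that floor lies within the scatter), concerns a different change and lies within the scatter, so no measured step bears directly on the furan-3-yl exchange. Compound 3 is therefore expected to stay close to compound 1, an expected step of a number no higher from compound 1 to compound 3 (the limit leaves the size open). Compound 3 is estimated at 100000 nM, within 40000 nM to 250000 nM.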

Compound 3, half-maximal cytotoxic concentration: > 100000 nM
Compound 3 gave a limit, no number; the forecaster's own chance of this, stated with the estimate: 60%; the middle value sits exactly at the limit.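

In this assay, compound 1 and compound 3 both stand at a limit, so no step between them can be read: the limit of > 100000 nM in this assay, at which 2 of the 3 values shown sit.

As far as these compounds go, how furan-3-yl compares with phenyl on the shared core therefore stays open.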